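The compounds below may be only part of what the source reports. "The series", "measured", "known", "first", "only" and "open" are said of these compounds alone.

Compound 1 `COc1cc(-c2nc3ccccc3s2)ccc1OCC(=O)NNC(=O)CN[C@@H](CS)C(=O)O` gives 1230 nM
Compound 2 `COc1cc(-c2nc3ccccc3s2)ccc1OCC(=O)NNC(=O)CN[C@@H](CCSC)C(=O)O` gives 1950 nM
Compound 3 `COc1cc(-c2nc3ccccc3s2)ccc1OCC(=O)NNC(=O)CNC(=N)NCCC[C@H](N[N+](=O)[O-])C(=O)O` gives 1960 nM

All three numbers come from a functional assay on MCF7 cells (Homo sapiens) for inhibition, read by MTT assay, with a stated time of 3 days (on this read-out higher numbers stand for weaker inhibition and lower numbers for stronger inhibition), and share one core. Compound 2 lies within the usual scatter of both compound 1 and compound 3, so it cannot be ranked against either.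

Compound 4 `CCOC(=O)[C@H](CS(=O)(=O)O)NCC(=O)NNC(=O)COc1ccc(-c2nc3ccccc3s2)cc1OC` has not been measured yet. It carries 1-(ethoxycarbonyl)-2-sulfoethyl in place of the 1-carboxy-3-(methylsulfanyl)propyl of compound 2 on an amine nitrogen (1-(ethoxycarbonyl)-2-sulfoethyl in place of 1-carboxy-3-(methylsulfanyl)propyl on an amine nitrogen).

Among the measured compounds shown here, only one measured step bears on this change, and only partly. Putting (methylsulfanyl)methyl in place of sulfanyl gave a 1.6-fold higher number from compound 1 to compound 2 (0.20 log units; within the scatter) and so altered the same group without leaving the scatter. For the measured compounds named here, no measured compound carries an ethoxycarbonyl or a sulfo group, so the data offer no direct guide to either one.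

Starting from compound 2 at 1950 nM and given the small size of that single step, no clear shift in either direction can be argued. The expected change in this assay is a 1.1-fold lower number from compound 2 to compound 4 (0.06 log units; within the scatter) and no step beyond the scatter is expected. From the compounds shown here alone, the margin stays wide, as both new groups are untested. For compound 4 the estimated value is 1700 nM with an expected range from 650 nM to 4500 nM on this read-out.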

Compound 4, half-maximal inhibitory concentration: 1990 nM
Beside the measured number, compound 4's estimate is 1.2-fold (0.07 log units) below it; measured number inside the range.
By their numbers in this assay, from the lowest: compounds 1, 2, 3 and 4 (each within the scatter of the next).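

In this assay, putting 1-(ethoxycarbonyl)-2-sulfoethyl in place of 1-carboxy-3-(methylsulfanyl)propyl on the amine nitrogen gives a 1.0-fold higher number from compound 2 to compound 4 (0.01 log units; within the scatter), and the same group in place of 1-carboxy-2-sulfanylethyl gives a 1.6-fold higher number from compound 1 to compound 4 (0.21 log units; within the scatter). The earlier step altered only the sulfur-bearing end of this group, whereas these two also replace the carboxy group with ethoxycarbonyl and bring in a sulfo group, and neither step leaves the scatter, so this position has now tolerated a larger rewrite of the group with no readable change in this read-out. Nothing measured on these compounds offers an explanation for this result.

From the compounds shown here alone, the ethoxycarbonyl and sulfo groups arrive together, so the share of each stays unknown, and a compound carrying only one of them would be needed to separate them. Going by these compounds, it also remains open whether a quite different group on this amine nitrogen, such as a benzyl group or a chain ending in a primary amine, would produce a step beyond the scatter.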